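Aryl selenium carbamates: growth inhibition in a non-tumour line

The source may report more compounds than this note shows. Statements on the series, on what has been measured and on what is new or still open speak of the compounds shown alone.

Measured so far in an ADME assay on 184B5 cells (Homo sapiens) for cytotoxicity, read by MTT assay, with a stated time of 72 h; a higher number here means a weaker inhibitor of growth, a lower number a stronger inhibitor of growth:

- compound 1 `CC(C)COC(=O)Nc1ccc([Se][Se]c2ccc(NC(=O)OCC(C)C)cc2)cc1` gives 5500 nM
- compound 2 `C=CCOC(=O)Nc1ccc([Se]C#N)cc1` gives 5000 nM
- compound 3 `O=C(Nc1ccc([Se][Se]c2ccc(NC(=O)OCc3ccc([N+](=O)[O-])cc3)cc2)cc1)OCc1ccc([N+](=O)[O-])cc1` gives 6000 nM

Compound 2 stands lowest of the three numbers in this assay, but its gap to compound 1 and its gap to compound 3 both lie within the scatter, so the three compounds are not separated by this assay. Within the data shown here, no pair among them differs in a single place, so no clean step is known.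

Compound 4 `N#C[Se]c1ccc(NC(=O)Oc2ccccc2)cc1` is the next member. Its difference from compound 2 is phenyl in place of allyl on an oxygen next to a carbonyl group. Among the measured compounds shown here, nothing among the measured compounds tells how a change at the oxygen of the carbamate moves the number: the diselenide pair, compound 1 and compound 3, carries two different groups there and still sits within the scatter of each other, and of compound 2.

On that basis no step beyond the scatter is expected from compound 2 to compound 4, and no change at the digits printed from compound 2 to compound 4 (within the scatter) is the expectation. Compound 4 is estimated at 5000 nM, with a range of 2500 nM to 10000 nM.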

Compound 4, concentration for 50% growth inhibition: 400 nM
The estimate for compound 4 lay 13-fold (1.10 log units) above the measured number; the whole stated range lies above it.
By their numbers in this assay, from the lowest: compound 4; then compounds 2, 1 and 3 (each within the scatter of the next).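

Phenyl in place of allyl on an oxygen next to a carbonyl group gives a 13-fold lower number from compound 2 to compound 4 (1.10 log units; beyond the scatter) in this assay, so a change at this oxygen can move the number well beyond the scatter. The earlier compounds shown here, all within the scatter of each other, gave no sign of this. No measurement at hand bears on why the number moves.

This single pair cannot separate the gain of the aromatic ring from the loss of the double bond outside aromatic rings, since the change brings both. Open too, on these data alone, is how a saturated propyl chain or a phenyl carrying an amine would read at this oxygen, and whether phenyl would have a similar effect in the diselenide compounds.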